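Chloro for methoxy on the phenyl arm of the series

The compounds below may be only part of what the source reports. "The series", "measured", "known", "first", "only" and "open" are said of these compounds alone.

Of the compounds shown here, three have so far been read in a functional assay on UO-31 cells (Homo sapiens) for inhibition, read by sulforhodamine B assay, with a stated time of 48 h, tested at 10 uM; a higher number here means more inhibition at the concentration tested (going by the name of the read-out), a lower number less inhibition. Compound 1 `c1ccc(-c2cn3ccnc3c(-c3ccc4ncn(C5CCCCC5)c4c3)n2)cc1` gives 55.2%. Compound 2 `COc1ccc(-c2cn3ccnc3c(-c3ccc4ncn(C5CCCCC5)c4c3)n2)cc1` gives 61.5%, the highest of the three numbers, but its separation from compound 1 is only a number 6.3 percentage points higher from compound 1 to compound 2 (within the scatter), which does not rank the two. Compound 3 `c1cn2cc(-c3ccsc3)nc(-c3ccc4ncn(C5CCCCC5)c4c3)c2n1` gives 23.1%; the steps to it are a number 32.1 percentage points lower from compound 1 to compound 3 (beyond the scatter) and a number 38.4 percentage points lower from compound 2 to compound 3 (beyond the scatter), the only large movements recorded, and both arise from exchanging the whole phenyl for thiophen-3-yl rather than from a substituent on it.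

Compound 4 `Clc1ccc(-c2cn3ccnc3c(-c3ccc4ncn(C5CCCCC5)c4c3)n2)cc1` has not been measured. Against compound 2 the difference is chloro in place of methoxy on an aromatic carbon. For the measured compounds named here, the one measured step at the same place on the phenyl ring, a number 6.3 percentage points higher from compound 1 to compound 2 (within the scatter), lies within the scatter, so a single substituent there has not yet moved the read-out. The two steps to compound 3 are of another kind, a change of the ring itself, and do not bear directly on a substituent swap. For compound 4 the expected step is therefore a number 4.5 percentage points lower from compound 2 to compound 4 (within the scatter), meaning no movement beyond the scatter in either direction. Compound 4 is estimated at 57%, with a range from 40% to 72%.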

Compound 4, a percentage reported as inhibition, at one concentration (the size of the read-out at that concentration, not a potency): 36.1%
Estimate against measurement, compound 4: 20.9 percentage points above, and the stated range ends above it.
By their numbers in this assay, from the lowest: compound 3; then compound 4; then compounds 1 and 2 (each within the scatter of the next).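

Chloro at this place, on an aromatic carbon para to a large group, gives the first step on the phenyl arm that is not a change of the ring itself and still moves the read-out in this assay: a number 19.1 percentage points lower from compound 1 to compound 4 (beyond the scatter) and a number 25.4 percentage points lower from compound 2 to compound 4 (beyond the scatter) are both modest, so a single substituent here is not neutral, and the swap of methoxy for chloro, one heavy atom in place of two, matters even though hydrogen and methoxy stay within the scatter of each other. The ring exchange also reads differently now, since a number 13 percentage points higher from compound 3 to compound 4 (beyond the scatter) places 4-chlorophenyl closer to thiophen-3-yl than the phenyl and 4-methoxyphenyl compounds are, and a substituted phenyl alone therefore does not secure the higher numbers. Nothing at hand explains why chloro separates from both hydrogen and methoxy at this place.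

With only hydrogen, methoxy and chloro at this place, the compounds shown do not tell whether the fall is particular to chloro or shared by other halogens such as fluoro or bromo. Nor do they show how a hydroxy group, a dimethylamino group or a carboxylic acid there would read at this single concentration.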